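Swapping Hydroxy for Fluoro on the Aromatic Ring

The source may hold more compounds than are shown below. What is called first, only, known or untested is meant among the compounds shown, and "the series" means these compounds.

In a functional assay on CCRF-CEM cells (Homo sapiens) for inhibition (a higher number here means a weaker inhibitor of growth, a lower number a stronger inhibitor of growth), compound 1 `COc1ccc(-n2cnnc2-c2cc(OC)c(OC)c(OC)c2)cc1` gives 1860 nM and compound 2 `COc1cc(-c2nncn2-c2ccc(N(C)C)cc2)cc(OC)c1OC` gives 61.7 nM. Compound 3 `COc1ccc(-n2cnnc2-c2cc(OC)c(OC)c(OC)c2)cc1O` gives 295 nM, the middle of the three numbers, clearly lower than that of compound 1 and clearly higher than that of compound 2. The next structure, compound 4 `COc1ccc(-n2cnnc2-c2cc(OC)c(OC)c(OC)c2)cc1F`, has fluoro in place of hydroxy on an aromatic carbon, ortho to a methoxy group: fluoro in place of hydroxy on an aromatic carbon. The most relevant measured change occurred at this same carbon, where hydroxy in place of hydrogen gave a modest step, a 6.3-fold lower number from compound 1 to compound 3 (0.80 log units; beyond the scatter). The large step of a 30-fold lower number from compound 1 to compound 2 (1.48 log units; beyond the scatter), from dimethylamino in place of methoxy, occurred elsewhere and offers less guidance. Within the data shown here, no measured compound carries fluoro, so the data cannot show how it compares with hydroxy or hydrogen. A modest move back toward the higher number of compound 1 is expected, and the estimated step is a 2.4-fold higher number from compound 3 to compound 4 (0.38 log units; beyond the scatter). For compound 4, the estimated value is 700 nM, with an expected range from 200 nM to 2400 nM.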

Compound 4, concentration for 50% growth inhibition: 2570 nM
The estimate for compound 4 lay 3.7-fold (0.56 log units) below the measured number; the whole stated range lies below it.
By their numbers in this assay, from the lowest: compound 2; then compound 3; then compounds 1 and 4 (each within the scatter of the next).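

Fluoro in place of hydroxy on this aromatic carbon gives an 8.7-fold higher number from compound 3 to compound 4 (0.94 log units; beyond the scatter) in this assay, so the gain from hydroxy does not carry over to another small group at this position. Fluoro in place of hydrogen gives a 1.4-fold higher number from compound 1 to compound 4 (0.14 log units; within the scatter), which leaves compound 1 and compound 4 indistinguishable, and of the three groups compared here on this carbon, only hydroxy lowers the number. Nothing measured here explains why hydroxy and fluoro differ at this position.

The compounds shown leave open how an amino group or a carboxylic acid on this same carbon would compare with hydroxy. They also leave open whether the gain from hydroxy would persist if dimethylamino replaced the methoxy group, as it does in compound 2.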